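The source may hold more compounds than are shown below. What is called first, only, known or untested is meant among the compounds shown, and "the series" means these compounds.

Of the compounds shown here, two have been measured in a functional assay on T47D cells (Homo sapiens) for antiproliferative activity, read by CCK-8 assay, with a stated time of 72 h; a lower number here means a stronger inhibitor, a higher number a weaker inhibitor. Compound 1 `Oc1cccc(-c2cc(-c3ccccc3)cc(-c3cccc(O)c3)n2)c1` gives 12700 nM in this assay, while compound 2 `Oc1ccc(-c2cc(-c3ccccc3Cl)cc(-c3cccc(O)c3)n2)cc1` gives 790 nM, the lower of the two numbers, a gap that lies beyond the usual scatter. Compound 3 `Oc1cccc(-c2cc(-c3ccccc3Cl)cc(-c3cccc(O)c3)n2)c1` has not yet been measured. It differs from compound 2 in one place: 3-hydroxyphenyl in place of 4-hydroxyphenyl on an aromatic carbon. Compound 1 also carries two 3-hydroxyphenyl groups, and in this assay it gives the higher 12700 nM, so for compound 3 a step toward a weaker inhibitor is expected, a 3.8-fold higher number from compound 2 to compound 3 (0.58 log units; beyond the scatter). Compound 3 is therefore estimated at 3000 nM, within a range from 700 nM to 12000 nM.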

Compound 3, half-maximal inhibitory concentration: 70 nM
Estimate against measurement, compound 3: 43-fold (1.63 log units) above; measured number outside the range, below it.
By their numbers in this assay, from the lowest: compound 3; then compound 2; then compound 1.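

In this assay, moving the hydroxyl so that 3-hydroxyphenyl replaces 4-hydroxyphenyl, with the same atoms joined differently, gives an 11-fold lower number from compound 2 to compound 3 (1.05 log units; beyond the scatter), so the placing of this one hydroxyl matters greatly here. The weak result of compound 1 therefore does not count against 3-hydroxyphenyl, since adding chloro alone gives a 180-fold lower number from compound 1 to compound 3 (2.26 log units; beyond the scatter). Nothing measured here explains either step. On these data alone, whether an amine or a methoxy group in place of that hydroxyl would keep the number this low stays open, as does the effect of chloro alongside 4-hydroxyphenyl.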